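The compounds below may be only part of what the source reports. "The series", "measured", "known", "first", "only" and "open" are said of these compounds alone.

Among the compounds with values here, compound 1 `COC(=O)/C=C/c1ccc(NCc2ccccc2O)cc1` is the lower of the two numbers so far in a functional assay on MDA-MB-231 cells (Homo sapiens) for antiproliferative activity, read by WST assay, with a stated time of 72 h (a lower number here means a stronger inhibitor, a higher number a weaker inhibitor), where compound 1 gives 31700 nM; its nearest neighbour is compound 2 `COC(=O)/C=C/c1ccc(NCc2cccc(OC)c2O)cc1`, which in this assay gives 73700 nM. Within the data shown here, the one measured step, a 2.3-fold higher number from compound 1 to compound 2 (0.37 log units; beyond the scatter), put a methoxy group in place of a hydrogen on the ring that carries the hydroxy group. Compound 3 `COC(=O)/C=C/c1ccc(NCc2cc([N+](=O)[O-])ccc2O)cc1` is built from the same core by the change (nitro in place of hydrogen on an aromatic carbon), a nitro group entering para to the hydroxy group and meta to a large group. Only the methoxy step bears on this, and it was modest and upward, so a step of similar or somewhat smaller size, upward or none beyond the scatter, is expected, that is a 1.3-fold higher number from compound 1 to compound 3 (0.12 log units; within the scatter). Compound 3 is therefore estimated at 42000 nM in this assay, within a range from 15000 nM to 120000 nM.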

Compound 3, half-maximal inhibitory concentration: 17400 nM
Compound 3: middle estimate off by 2.4-fold (0.38 log units), on the high side; measured number inside the range.
By their numbers in this assay, from the lowest: compounds 3 and 1 (each within the scatter of the next); then compound 2.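

In this assay, nitro in place of hydrogen on an aromatic carbon, para to a hydroxy group and meta to a large group, gives a 1.8-fold lower number from compound 1 to compound 3 (0.26 log units; within the scatter). Within the data shown here, this position of the core of compound 1 therefore accepts a group of 3 heavy atoms with no change beyond the scatter, whereas the only earlier step, a 2.3-fold higher number from compound 1 to compound 2 (0.37 log units; beyond the scatter), showed a methoxy group elsewhere on the same ring going beyond it. No information is available to explain this outcome.

From the compounds shown here alone, whether an amine, a carboxylic acid or a methoxy group at this same position would also stay within the scatter remains open. So does whether a nitro group on another carbon of this ring would give a similar number in this assay.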